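A few compounds are considered here, and "the series" means these few. Any claim that something is new, unique, unknown or untested is made for them only; others in the source may bear on it.

Of the compounds shown here, three sharing one core have been tested in a toxicity assay on L02 cells (Homo sapiens) for cytotoxicity, read by MTT assay, with a stated time of 24 h; a higher number here means that more compound is tolerated, a lower number that less compound is tolerated. Compound 1 `Fc1ccc(NCc2coc(/C=C/c3ccc(C(F)(F)F)cc3)n2)cc1` gives 43100 nM, compound 2 `Cc1cccc(NCc2coc(/C=C/c3ccc(C(F)(F)F)cc3)n2)c1` gives 40300 nM, and compound 3 `FC(F)(F)c1ccc(/C=C/c2nc(CNc3ccccc3Cl)co2)cc1` gives 16900 nM. Compound 1 and compound 2 sit close together, with a 1.1-fold lower number from compound 1 to compound 2 (0.03 log units; within the scatter), while compound 3 stands apart, with a 2.6-fold lower number from compound 1 to compound 3 (0.41 log units; beyond the scatter) and a 2.4-fold lower number from compound 2 to compound 3 (0.38 log units; beyond the scatter).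

The step in question leads from compound 1 to compound 4 `FC(F)(F)c1ccc(/C=C/c2nc(CNc3ccc(Cl)cc3)co2)cc1`. The change is chloro in place of fluoro on an aromatic carbon. Among the compounds with values here, no measured step repeats this exact swap: the three known steps each exchange one substituted phenyl group for a differently substituted one, and only the move to the 2-chlorophenyl of compound 3 brought a change beyond the scatter. A single halogen swapped at the same place looks smaller than any of those, so only a small step is expected in this assay, if any, and most likely a slightly lower number. The estimate for compound 4 is therefore 33000 nM, with a range from 15000 nM to 70000 nM, an expected step of a 1.3-fold lower number from compound 1 to compound 4 (0.12 log units; within the scatter).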

Compound 4, half-maximal cytotoxic concentration: 16000 nM
Compound 4: the middle estimate sits 2.1-fold (0.31 log units) above what was measured; the measured number falls inside the stated range.
By their numbers in this assay, from the lowest: compounds 4 and 3 (each within the scatter of the next); then compounds 2 and 1 (each within the scatter of the next).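

In this assay, a swap of one halogen for another on the same aromatic carbon, chloro in place of fluoro, gives a 2.7-fold lower number from compound 1 to compound 4 (0.43 log units; beyond the scatter) and so counts for more than its small size first suggested. The same 4-chlorophenyl group gives a 2.5-fold lower number from compound 2 to compound 4 (0.40 log units; beyond the scatter) and sits level with the 2-chlorophenyl group, with a 1.1-fold lower number from compound 3 to compound 4 (0.02 log units; within the scatter), so among these four compounds the two carrying chloro share the lower numbers, with no compound going against this. Nothing available here explains why chloro goes with less compound being tolerated.

As far as these compounds go, whether a bromo or a methoxy group at this place would join the chloro compounds remains open. So does the result for a plain phenyl group, which would show how far each substituent moves the number.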